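Trimming the Bicyclic Amine Down to an Amino Group

The source may report more compounds than this note shows. Statements on the series, on what has been measured and on what is new or still open speak of the compounds shown alone.

Compound 1 `O=C(CCc1ccc(C(F)(F)F)cc1)Nc1ccc2nc(N3CC4CC3CN4)ccc2c1` was measured in an assay on isolated protein for displacement of a labelled ligand from melanin-concentrating hormone receptor 1 (Homo sapiens) (on this read-out higher numbers stand for weaker inhibition and lower numbers for stronger inhibition), and gave 210 nM. That is the highest of the three numbers recorded: compound 2 `O=C(CCc1ccc(C(F)(F)F)cc1)Nc1ccc2nc(N3CCC(c4ccccc4)C3)ccc2c1` gives 25 nM, and compound 3 `CC(C)C(=O)NC1CCN(c2ccc3cc(NC(=O)CCc4ccc(C(F)(F)F)cc4)ccc3n2)C1` gives 1 nM. Both steps away from compound 1 replace the same group that is at issue here, and both lower the number: an 8.4-fold lower number from compound 1 to compound 2 (0.92 log units; beyond the scatter), and a 210-fold lower number from compound 1 to compound 3 (2.32 log units; beyond the scatter). Compound 4 `Nc1ccc2cc(NC(=O)CCc3ccc(C(F)(F)F)cc3)ccc2n1` has not yet been measured. It differs from compound 1 in one place: one nitrogen atom in place of a group of 7 heavy atoms (5 carbon, 2 nitrogen; 2 five-membered non-aromatic rings with 1 hetero atom each), on an aromatic carbon. Going by the values given here, no measured step puts a single atom at that position; the two steps that leave compound 1 both install a larger group in its place, so they are the only guide. They show that the group can be changed without loss, but say nothing about what a lone nitrogen does there. The step from compound 1 to compound 4 is therefore expected to raise the number, at a 7.1-fold higher number from compound 1 to compound 4 (0.85 log units; beyond the scatter). Compound 4 is estimated at 1500 nM, within a range of 300 nM to 8000 nM.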

Compound 4, half-maximal inhibitory concentration: 240 nM
Compound 4: middle estimate off by 6.3-fold (0.80 log units), on the high side, and the stated range ends above it.
By their numbers in this assay, from the lowest: compound 3; then compound 2; then compounds 1 and 4 (each within the scatter of the next).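

Amino on this aromatic carbon does as well as the group of compound 1: a 1.1-fold higher number from compound 1 to compound 4 (0.06 log units; within the scatter) in this assay, so that group's two rings and extra heavy atoms bring no measurable gain over amino. Size alone therefore does not set the number here, since the larger 3-phenylpyrrolidin-1-yl group stands clearly apart from amino, with a 9.6-fold higher number from compound 2 to compound 4 (0.98 log units; beyond the scatter), and 3-((isopropylcarbonyl)amino)pyrrolidin-1-yl further still, with a 240-fold higher number from compound 3 to compound 4 (2.38 log units; beyond the scatter). Nothing in the data given explains why these groups differ.

The compounds shown leave open whether an unsubstituted pyrrolidin-1-yl group would sit with compound 4 or with the two substituted pyrrolidines. They also leave open how much of the low number of compound 3 would survive with a 3-aminopyrrolidin-1-yl group, which lacks the isopropylcarbonyl part.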